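Returning a pyrazole to the amide nitrogen

The compounds below may be only part of what the source reports. "The series", "measured", "known", "first", "only" and "open" are said of these compounds alone.

Measured compounds:
compound 1, `Cc1ccc(OCC(=O)N(Cc2cccs2)c2ccnn2C)cc1`: 422 nM
compound 2, `Cc1ccc(OCC(=O)N(Cc2cccs2)C(C)(C)C)cc1`: 11000 nM

Among the compounds with values here, in an assay on HEK293 cells for agonist activity at transient receptor potential cation channel subfamily M member 8 (Homo sapiens), read by fluorescence and calcium flux, with a stated time of 15 min (on this read-out lower numbers stand for an effect already at smaller amounts and higher numbers for an effect only at larger amounts of compound), compound 2 gives the highest of the two numbers, with compound 1 as its only neighbour. Compound 3, `Cc1ccc(OCC(=O)N(Cc2cccs2)c2c(C)n[nH]c2C)cc1`, carries 3,5-dimethyl-1H-pyrazol-4-yl in place of tert-butyl on an amide-type nitrogen. Within the data shown here, the one measured step that bears on this, a 26-fold higher number from compound 1 to compound 2 (1.42 log units; beyond the scatter), went the opposite way: removing a pyrazole in favour of tert-butyl raised the number strongly. Putting a different pyrazole back is therefore expected to lower the number again by a large amount, a 14-fold lower number from compound 2 to compound 3 (1.14 log units; beyond the scatter). Compound 3 is estimated at 800 nM, within 250 nM to 3000 nM.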

Compound 3, half-maximal effective concentration: 0.3 nM
Compound 3: middle estimate off by 2700-fold (3.43 log units), on the high side, outside the stated range (below it).
By their numbers in this assay, from the lowest: compound 3; then compound 1; then compound 2.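

On the amide-type nitrogen, the group decides far more than compound 1 and compound 2 suggested: 3,5-dimethyl-1H-pyrazol-4-yl in place of tert-butyl gives the largest change so far (a 37000-fold lower number from compound 2 to compound 3 (4.56 log units; beyond the scatter)). The two pyrazoles are not interchangeable either, with 3,5-dimethyl-1H-pyrazol-4-yl in place of 1-methyl-1H-pyrazol-5-yl still giving a large drop (a 1400-fold lower number from compound 1 to compound 3 (3.15 log units; beyond the scatter)). Nothing measured here explains either drop.

Which part of the 3,5-dimethyl-1H-pyrazol-4-yl group matters, its two methyl groups or its ring hydrogen on nitrogen, stays open. So does how a phenyl or pyridine ring would read at this nitrogen.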